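Nitro to Trifluoromethyl on the Benzoyl Arm

A few compounds are considered here, and "the series" means these few. Any claim that something is new, unique, unknown or untested is made for them only; others in the source may bear on it.

Measured compounds:
compound 1, `CN(C(=O)NC(=O)c1ccc([N+](=O)[O-])cc1)c1nc(C(F)(F)F)c(C(=O)N/N=C/c2cccc(C(F)(F)F)c2)s1`, 5.42 ug/mL
compound 2, `CN(C(=O)NC(=O)c1ccc([N+](=O)[O-])cc1)c1nc(C(F)(F)F)c(C(=O)N/N=C/c2ccc([N+](=O)[O-])cc2)s1`, 8.98 ug/mL
compound 3, `CN(C(=O)NC(=O)c1c(Cl)cccc1Cl)c1nc(C(F)(F)F)c(C(=O)N/N=C/c2ccccc2C(F)(F)F)s1`, 12 ug/mL

In a functional assay on A549 cells (Homo sapiens) for inhibition, read by MTT assay, with a stated time of 72 h (on this read-out higher numbers stand for weaker inhibition and lower numbers for stronger inhibition), compound 1 gives the lowest of the three numbers; compound 2 sits nearest, and compound 3 furthest, its number being beyond the scatter from that of compound 1. Compound 4, `CN(C(=O)NC(=O)c1ccc(C(F)(F)F)cc1)c1nc(C(F)(F)F)c(C(=O)N/N=C/c2cccc(C(F)(F)F)c2)s1`, has not been measured. It differs from compound 1 in one place: trifluoromethyl in place of nitro on an aromatic carbon. Among the measured compounds shown here, the only single-point step among the measured compounds, a 1.7-fold higher number from compound 1 to compound 2 (0.22 log units; within the scatter), concerns a different place, the aromatic ring on the carbon with a double bond to nitrogen, and is within the scatter. Compound 3 differs from compound 1 in two places at once, so its value cannot be split between them. For the measured compounds named here, no measured step bears directly on the change from compound 1 to compound 4. The expectation is therefore a step of a 1.1-fold higher number from compound 1 to compound 4 (0.04 log units; within the scatter), none beyond the scatter. Compound 4 is estimated at 6 ug/mL, with a range from 3 ug/mL to 13 ug/mL.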

Compound 4, half-maximal inhibitory concentration: 6.66 ug/mL
Beside the measured number, compound 4's estimate is 1.1-fold (0.05 log units) below it, within the range that was stated.
By their numbers in this assay, from the lowest: compounds 1, 4, 2 and 3 (each within the scatter of the next, the first and the last beyond it).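

Among the compounds shown here, the benzoyl arm, which the one earlier step did not touch, now has a reading of its own: in this assay, trifluoromethyl in place of nitro on an aromatic carbon para to a large group gives a 1.2-fold higher number from compound 1 to compound 4 (0.09 log units; within the scatter), so this read-out does not tell the two groups apart at this position. The position thus takes a group with no hydrogen-bond acceptors in place of one that has them, with no shift beyond the scatter. Nothing given about these compounds offers a reason for this result.

On these data alone, whether an amine or a carboxylic acid would read the same at this position remains open. Also open, as far as these compounds go, is whether the same exchange would read alike with the 4-nitrophenyl of compound 2 on the carbon with a double bond to nitrogen.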